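Side-chain amine variation on a thienopyrimidine urea series

The compounds below may be only part of what the source reports. "The series", "measured", "known", "first", "only" and "open" are said of these compounds alone.

Measured compounds:
compound 1 `CN(C)CCNc1nc(-c2ccc(NC(=O)Nc3ccccc3)cc2)nc2ccsc12` 620 nM
compound 2 `CN(C)CCNc1nc(-c2ccc(NC(=O)Nc3ccccc3F)cc2)nc2ccsc12` 510 nM
compound 3 `Cc1ccc(NC(=O)Nc2ccc(-c3nc(NCCN(C)C)c4sccc4n3)cc2)cc1` 2150 nM

In a functional assay on HT-29 cells (Homo sapiens) for cytotoxicity, read by MTT assay, with a stated time of 72 h (on this read-out higher numbers stand for weaker inhibition and lower numbers for stronger inhibition), compound 1 gives 620 nM, the second highest of the three numbers. Its nearest neighbour is compound 2, the step being a 1.2-fold lower number from compound 1 to compound 2 (0.08 log units; within the scatter); furthest away is compound 3, with a 3.5-fold higher number from compound 1 to compound 3 (0.54 log units; beyond the scatter). Between the other two, the step is a 4.2-fold higher number from compound 2 to compound 3 (0.62 log units; beyond the scatter).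

Compound 4 `CCN(CC)CCCNc1nc(-c2ccc(NC(=O)Nc3ccccc3)cc2)nc2ccsc12` differs from compound 1 at the other end of the molecule: (diethylamino)methyl in place of dimethylamino on a saturated chain carbon, two bonds along the chain from a nitrogen on an aromatic ring. Within the data shown here, none of the measured steps touches this part of the structure; all three concern the aryl group on the urea. The data therefore give no direct guide to the size or direction of this change, and the step is expected to be no change at the digits printed from compound 1 to compound 4 (within the scatter), that is, no change beyond the scatter. In this assay compound 4 is accordingly estimated at 620 nM, with a range from 250 nM to 1600 nM.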

Compound 4, half-maximal inhibitory concentration: 730 nM
The estimate for compound 4 lay 1.2-fold (0.07 log units) below the measured number; the range from low to high includes it.
By their numbers in this assay, from the lowest: compounds 2, 1 and 4 (each within the scatter of the next); then compound 3.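

The side chain moves from (2-(dimethylamino)ethyl)amino to (3-(diethylamino)propyl)amino, and in this assay the step is a 1.2-fold higher number from compound 1 to compound 4 (0.07 log units; within the scatter), so this change at the amine end leaves the number within the scatter. The earlier steps shown here concerned only the aryl group on the urea, whereas this one shows that, for this pair, replacing dimethylamino with the larger (diethylamino)methyl at this position produces no step beyond the scatter. Nothing measured here gives a reason for this result.

Chain length and the substituents on the amine change together in this single step, and the compounds shown do not separate the two. Going by these compounds, it also remains open whether a ring amine such as morpholine or piperazine would stay in the same range, and whether the same side-chain change would hold with 2-fluorophenyl or 4-methylphenyl on the urea.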